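Swapping the octyl tail for a chlorophenoxy group

The source may report more compounds than this note shows. Statements on the series, on what has been measured and on what is new or still open speak of the compounds shown alone.

Of the compounds shown here, three built on one shared core have been measured in an ADME assay on S9 fraction from liver (Rattus norvegicus) for metabolic stability, read by LC-MS, using NADPH, with a stated time of 30 min; a higher number here means that more of the compound is left, a lower number that less of the compound is left. Compound 1 `CCCCCCCCc1ccc(OCC(=O)Cn2nnc(C)n2)cc1` sits at the limit of the assay, giving < 5%, a limit rather than a number (the limit of < 5% in this assay, at which 1 of the 3 values shown sits). Compound 2 `CCCCCCCCc1ccc(OCC(=O)Cn2nnc(-c3ccccc3)n2)cc1` gives 33%, and the change a number at least 28 percentage points higher from compound 1 to compound 2 (beyond the scatter) is beyond the usual scatter. Compound 3 `CCCCCCCCc1ccc(OC(C)C(=O)Cn2nnc(-c3ccccc3)n2)cc1` gives 40%, the higher of the two actual numbers, yet the step of a number 7 percentage points higher from compound 2 to compound 3 (within the scatter) stays within the scatter, so compound 2 and compound 3 cannot be told apart.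

Compound 4 `CC(Oc1ccc(Oc2ccc(Cl)cc2)cc1)C(=O)Cn1nnc(-c2ccccc2)n1` differs from compound 3 by 4-chlorophenoxy in place of octyl on an aromatic carbon. Within the data shown here, neither measured step touches this part of the molecule: one replaced methyl with phenyl on the aromatic carbon, the other added a methyl on the chain carbon, so no measured step bears on the new change and the data give no direction for it. The expected step of a number 2 percentage points higher from compound 3 to compound 4 (within the scatter) is therefore none beyond the scatter, with wide uncertainty. Compound 4 is estimated at 42%, between 15% and 75%.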

Compound 4, percent of the compound remaining: < 5%
Compound 4: no number, only a limit (the forecaster's own chance of this, stated with the estimate: 8%); middle value at least 37 percentage points away from the limit.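

Among these compounds, with 4-chlorophenoxy in place of octyl on the aromatic carbon, this assay shows a number at least 35 percentage points lower from compound 3 to compound 4 (beyond the scatter), so this position, which no earlier step touched, can matter a great deal. Compound 4 gives < 5%, which is a limit and not a number. The phenyl of compound 3 is still present in compound 4, yet compound 4 sits at the limit of the assay, and the phenyl alone therefore does not keep a compound off that limit: the limit of < 5% in this assay, at which 2 of the 4 values shown sit.

This single change cannot separate the parts of the new group, so the ether oxygen, the chlorine and the added ring remain unresolved. As far as these compounds go, how a plain phenoxy group, a butyl chain or an amine would read at this place stays open.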